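The source may hold more compounds than are shown below. What is called first, only, known or untested is meant among the compounds shown, and "the series" means these compounds.

Compound 1 `CCC1C(=O)N(C)c2cnc(-n3ccc4cc(C(=O)NC)ccc43)nc2N1c1ccn(C)n1` gives 43100 nM in this list
Compound 2 `CCCCNS(=O)(=O)c1ccc(Nc2ncc3c(n2)N(C2CCCC2)[C@H](CC)C(=O)N3C)cc1` gives 477 nM in this list
Compound 3 `CCC1C(=O)N(C)c2cnc(Nc3ccc(S(=O)(=O)NCCCO)cc3)nc2N1c1ccn(C)n1` gives 48900 nM in this list

In a functional assay on A549 cells (Homo sapiens) for antiproliferative activity, read by CCK-8 assay, with a stated time of 72 h (a higher number here means a weaker inhibitor of growth, a lower number a stronger inhibitor of growth), compound 1 stands level with compound 3 within the scatter, while compound 2 has a far lower number and so is a much stronger inhibitor of growth.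

Among the measured compounds shown here, compound 4 `CCC1C(=O)N(C)c2cnc(-n3ccc4cc(C(=O)NC5CCCC5)ccc43)nc2N1c1ccn(C)n1` keeps the rest of compound 1 but has cyclopentyl in place of methyl on an amide-type nitrogen as its one change. For the measured compounds named here, no measured pair shows this change alone. Compound 2 at 477 nM also carries a cyclopentyl group but differs from compound 1 in more than one place, so it gives only weak support. A modest move toward a lower number is expected in this assay as the estimated step of a 2.2-fold lower number from compound 1 to compound 4 (0.33 log units; beyond the scatter) with wide uncertainty. Compound 4 is estimated at 20000 nM within a range of 5000 nM to 60000 nM for now.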

Compound 4, concentration for 50% growth inhibition: 39500 nM
Compound 4: middle estimate off by 2.0-fold (0.30 log units), on the low side; low and high end bracket the measured number.
By their numbers in this assay, from the lowest: compound 2; then compounds 4, 1 and 3 (each within the scatter of the next).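

In this assay, among the compounds shown here, this is the first measured pair that isolates a single change on the amide-type nitrogen: cyclopentyl in place of methyl gives a 1.1-fold lower number from compound 1 to compound 4 (0.04 log units; within the scatter). Going from one carbon to a five-membered ring of carbon therefore does not separate these two compounds, and the number stays high for both. Nothing available here offers an explanation for this result.

Still open, from the compounds shown here alone, is whether a group of another kind on this nitrogen, such as a chain ending in an amine or a carboxylic acid, would shift the number. Whether a change elsewhere on the core of compound 1 would matter more also remains unanswered.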